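Replacing 5-bromo-1H-indol-3-yl with 2,5-dimethylphenyl: working notes

A few compounds are considered here, and "the series" means these few. Any claim that something is new, unique, unknown or untested is made for them only; others in the source may bear on it.

In a functional assay on DU-145 cells (Homo sapiens) for inhibition, read by trypan blue exclusion, with a stated time of 96 h (on this read-out higher numbers stand for weaker inhibition of growth and lower numbers for stronger inhibition of growth), compound 3 `Cc1ccc(CS(=O)(=O)/C(=C/c2c[nH]c3ccc(Br)cc23)C(=O)c2ccc(Cl)cc2)cc1` gives 10000 nM, the second highest of three numbers. Compound 1 `Cc1ccc(CS(=O)(=O)/C(=C/c2ccc(N(C)C)cc2)C(=O)c2ccc(Cl)cc2)cc1` gives 50000 nM, and compound 2 `Cc1ccc(S(=O)(=O)/C(=C/c2cc(C)ccc2C)C(=O)c2ccc(Cl)cc2)cc1` gives 1000 nM. Compound 4 `Cc1ccc(CS(=O)(=O)/C(=C/c2cc(C)ccc2C)C(=O)c2ccc(Cl)cc2)cc1` follows from compound 3 through (2,5-dimethylphenyl in place of 5-bromo-1H-indol-3-yl on a double-bonded chain carbon bound to a double-bonded chain carbon), with 2,5-dimethylphenyl in place of 5-bromo-1H-indol-3-yl on a double-bonded chain carbon bound to a double-bonded chain carbon. Among the compounds with values here, the one measured step at this place, a 5.0-fold lower number from compound 1 to compound 3 (0.70 log units; beyond the scatter), is modest and beyond the scatter. Compound 2 also carries 2,5-dimethylphenyl and sits lower at 1000 nM, though its core is not that of compound 4. A modest downward step in this assay is therefore expected. The expected step is a 3.3-fold lower number from compound 3 to compound 4 (0.52 log units; beyond the scatter). For compound 4 the estimated value is 3000 nM, with an expected range from 800 nM to 10000 nM.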

Compound 4, concentration for 50% growth inhibition: 1000 nM
The estimate for compound 4 lay 3.0-fold (0.48 log units) above the measured number; the range from low to high includes it.
By their numbers in this assay, from the lowest: compounds 2 and 4 (each within the scatter of the next); then compound 3; then compound 1.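

In this assay, 2,5-dimethylphenyl on a double-bonded chain carbon bound to a double-bonded chain carbon gives stronger growth inhibition than either other group on this core (a 10-fold lower number from compound 3 to compound 4 (1.00 log units; beyond the scatter); a 50-fold lower number from compound 1 to compound 4 (1.70 log units; beyond the scatter)), the second step being large. With 2,5-dimethylphenyl in place, 4-methylbenzyl on a sulfonyl sulfur reads the same as 4-methylphenyl (no change at the digits printed from compound 2 to compound 4 (within the scatter)). The series leaves open whether a 2-phenylethyl chain on the sulfonyl sulfur, or 2,5-dichlorophenyl on the double-bonded chain carbon, would keep this level. No measured evidence bears on the cause of these steps.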